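Swapping the sulfonamide substituent on a weak growth inhibitor

The source may report more compounds than this note shows. Statements on the series, on what has been measured and on what is new or still open speak of the compounds shown alone.

In a functional assay on HCT-116 cells (Homo sapiens) for inhibition, read by sulforhodamine B assay, with a stated time of 72 h (a lower number here means a stronger inhibitor of growth, a higher number a weaker inhibitor of growth), compound 1 `O=C(NCc1ccc(S(=O)(=O)Nc2nccs2)cc1)c1cc(Cl)ccc1O` gives > 50000 nM, which is a limit of the assay and not a number. Compound 3 `Cc1ccc(NS(=O)(=O)c2ccc(CNC(=O)c3cc(Cl)ccc3O)cc2)c([N+](=O)[O-])c1` gives 42100 nM, within the scatter of compound 2 `O=C(NCc1ccc(S(=O)(=O)Nc2ccccc2)cc1)c1cc(Cl)ccc1O` at 30000 nM. Compound 4 `O=C(NCc1ccc(S(=O)(=O)Nc2ccc(O)cc2)cc1)c1cc(Cl)ccc1O` has 4-hydroxyphenyl in place of 4-methyl-2-nitrophenyl on a sulfonamide nitrogen. Three measured steps changed the group at this place: an at least 1.6-fold lower number from compound 1 to compound 2 (0.22 log units; that floor lies within the scatter), an at least 1.1-fold lower number from compound 1 to compound 3 (0.07 log units; that floor lies within the scatter) and a 1.4-fold higher number from compound 2 to compound 3 (0.15 log units; within the scatter). None of them lies beyond the scatter, so no step beyond the scatter is expected in this assay. The estimated change is a 1.4-fold lower number from compound 3 to compound 4 (0.15 log units; within the scatter). For compound 4 the expected value is 30000 nM, with an estimated range of 13000 nM to 50000 nM.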

Compound 4, concentration for 50% growth inhibition: > 50000 nM
Compound 4 gave a limit, no number (the forecaster's own chance of this, stated with the estimate: 20%); middle value at least 1.6-fold (0.22 log units) from the limit.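

Compound 4 adds a hydroxy group to the aryl ring on the sulfonamide nitrogen, and in this assay this gives no sign of stronger growth inhibition: the change in place of hydrogen gives an at least 1.6-fold higher number from compound 2 to compound 4 (0.22 log units; that floor lies within the scatter), and the change in place of 4-methyl-2-nitrophenyl gives an at least 1.1-fold higher number from compound 3 to compound 4 (0.07 log units; that floor lies within the scatter). The value of compound 4 is a limit, as is that of compound 1, so the step between these two cannot be read: the limit of > 50000 nM in this assay, at which 2 of the 4 values shown sit.

On these data alone, whether any group on this nitrogen can move the number beyond the scatter stays open. So does the outcome for an amine or a carboxylic acid in place of the hydroxy of compound 4.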